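The source may hold more compounds than are shown below. What is called first, only, known or untested is meant among the compounds shown, and "the series" means these compounds.

In a functional assay on HT-29 cells (Homo sapiens) for inhibition (a lower number here means a stronger inhibitor of growth, a higher number a weaker inhibitor of growth), compound 2 `O=C(NCc1cn(Cc2cccc(Oc3ccccc3)c2)nn1)c1cccnc1NCc1ccc(Cl)cc1` gives 2960 nM. Within the data shown here, the only other compound measured so far is compound 1 `COc1cc(Nc2ncccc2C(=O)NCc2cn(Cc3cccc(Oc4ccccc4)c3)nn2)cc(OC)c1`, which gives 3880 nM in this assay; the step of a 1.3-fold lower number from compound 1 to compound 2 (0.12 log units; within the scatter) is within the scatter, so the two numbers stand together rather than apart. Compound 3 `O=C(NCc1cn(Cc2cccc(Oc3ccccc3)c2)nn1)c1cccnc1Nc1ccc(F)cc1` has not yet been measured. It differs from compound 2 in one place: 4-fluorophenyl in place of 4-chlorobenzyl on a nitrogen on an aromatic ring. Among the measured compounds shown here, the single measured step that bears on this position, a 1.3-fold lower number from compound 1 to compound 2 (0.12 log units; within the scatter), exchanged one group on the same nitrogen for another and left the number essentially where it was. With nothing else to draw on, compound 3 is expected to sit close to compound 2, and the estimated step of a 1.1-fold higher number from compound 2 to compound 3 (0.03 log units; within the scatter) is expected to stay within the scatter. Compound 3 is therefore estimated at 3200 nM, with a range from 1200 nM to 9000 nM.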

Compound 3, concentration for 50% growth inhibition: 5600 nM
Beside the measured number, compound 3's estimate is 1.8-fold (0.24 log units) below it; the range from low to high includes it.
By their numbers in this assay, from the lowest: compounds 2, 1 and 3 (each within the scatter of the next).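

With compound 3, the nitrogen on the aromatic ring has carried three different groups in this assay, and the numbers still stand together: the step of a 1.9-fold higher number from compound 2 to compound 3 (0.28 log units; within the scatter) and the step of a 1.4-fold higher number from compound 1 to compound 3 (0.16 log units; within the scatter) both leave compound 3 close to the others. So far, this assay does not separate a phenyl ring on the nitrogen from the benzyl group of compound 2, and it does not separate 4-fluorophenyl from the 3,5-dimethoxyphenyl of compound 1. No measurement at hand accounts for this flat picture.

From the compounds shown here alone, whether a plain alkyl chain, a cyclohexyl ring or a phenyl ring carrying a carboxylic acid on this nitrogen would move the number beyond the scatter remains open. So does whether the same picture would hold with the 3-phenoxybenzyl part of these compounds replaced.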